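A few compounds are considered here, and "the series" means these few. Any claim that something is new, unique, unknown or untested is made for them only; others in the source may bear on it.

Measured so far in a functional assay on HT-29 cells (Homo sapiens) for cytotoxicity, read by MTT assay, with a stated time of 72 h; a higher number here means a weaker inhibitor, a lower number a stronger inhibitor:
Compound 1 `N[C@H]1CC[C@H](Nc2c(C(=O)NCc3ccc(F)cc3)nc(N3CCCCS3(=O)=O)c3cccnc23)CC1`: > 10000 nM
Compound 2 `NCCCNc1c(C(=O)NCc2ccc(F)cc2)nc(Br)c2cccnc12`: "not determined" (no result reported)
Compound 3 `CC(C)(C)OC(=O)N1CCN(c2c(C(=O)NCc3ccc(F)cc3)nc(Br)c3cccnc23)CC1`: > 10000 nM

Compound 2 stands without a number, and the record for compound 2 reads "not determined" (no result reported). Compound 1 gives > 10000 nM, which is a limit and not a number. Compound 3 gives > 10000 nM, which is also a limit. The picture so far is therefore (the limit of > 10000 nM in this assay, at which 2 of the 3 values shown sit).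

Compound 4 `CN(C)CCCNc1c(C(=O)NCc2ccc(F)cc2)nc(Br)c2cccnc12` has not yet been measured. The change dimethylamino in place of amino on a saturated chain carbon, three bonds along the chain from a nitrogen on an aromatic ring puts dimethylamino in place of amino on a saturated chain carbon, three bonds along the chain from a nitrogen on an aromatic ring.

Among the compounds with values here, no measured step can size this change, so the step expected in this assay is none beyond the scatter, in neither direction. For compound 4 the estimated value is 8000 nM, expected to lie between 2000 nM and 20000 nM.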

Compound 4, half-maximal inhibitory concentration: 6000 nM
The estimate for compound 4 lay 1.3-fold (0.12 log units) above the measured number; measured number inside the range.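

Compound 4 gives 6000 nM, but compound 2 has no reported result to set against it, so no step can be read between them. Left open is what dimethylamino in place of amino does in this assay, and the other values shown are limits, not numbers: the limit of > 10000 nM in this assay, at which 2 of the 4 values shown sit.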